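Ethynyl in place of furan-3-yl on the shared core

The compounds below may be only part of what the source reports. "The series", "measured", "known", "first", "only" and "open" are said of these compounds alone.

Compound 3 `Cc1nc(N)c2c(-c3ccoc3)cn([C@@H]3O[C@H](CO)[C@@H](O)[C@H]3O)c2n1` gives > 100000 nM in an ADME assay on BJ cells (Homo sapiens), read by MTT assay, with a stated time of 72 h (a lower number here means a stronger inhibitor, a higher number a weaker inhibitor), which is a limit of the assay and not a number. Its place in the series is thus (the limit of > 100000 nM in this assay, at which 1 of the 3 values shown sits). Compound 4 `C#Cc1cn([C@@H]2O[C@H](CO)[C@@H](O)[C@H]2O)c2nc(C)nc(N)c12` carries ethynyl in place of furan-3-yl on an aromatic carbon of the shared core: ethynyl in place of furan-3-yl on an aromatic carbon.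

Among the measured compounds shown here, no measured step covers this exchange, and a limit gives no starting number from which to size it. The nearest evidence comes from two other compounds that carry ethynyl. In this assay, compound 1 `C#Cc1cn([C@@H]2O[C@H](CO)[C@@H](O)[C@H]2O)c2ncnc(N(C)C)c12` gives 410 nM and compound 2 `C#Cc1cn([C@@H]2O[C@H](CO)[C@@H](O)[C@H]2O)c2ncnc(C)c12` gives 50 nM. For the measured compounds named here, the one measured step between them, an 8.2-fold lower number from compound 1 to compound 2 (0.91 log units; beyond the scatter), is methyl in place of dimethylamino on an aromatic carbon. It is modest, lies beyond the scatter and leaves the ethynyl group untouched, so it bears on the exchange only indirectly. It shows that values among ethynyl compounds still move with changes elsewhere on the core, and compound 4 differs from both compounds at such places.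

A lower number is therefore expected, resting on compound 1 at 410 nM, but with a wide margin. The expected change is an at least 33-fold lower number from compound 3 to compound 4 (1.52 log units; beyond the scatter). For compound 4 the estimate is 3000 nM, with an expected range of 200 nM to 50000 nM.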

Compound 4, half-maximal inhibitory concentration: > 100000 nM
Compound 4 gave a limit, no number; the forecaster's own chance of this, stated with the estimate: 15%; middle value at least 33-fold (1.52 log units) away from the limit.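

Compound 3 and compound 4 both stand at a limit of the assay and not at a number, so no step can be read for ethynyl in place of furan-3-yl on the shared core: the limit of > 100000 nM in this assay, at which 2 of the 4 values shown sit.

The compounds shown leave open whether this exchange changes the value in this assay at all, and in which direction.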